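This account rests on a few compounds, and the source may have more. Where it says the series, first, only, none or still open, it means among the compounds named here.

Measured in a functional assay on HL-60 cells (Homo sapiens) for antiproliferative activity; a lower number here means a stronger inhibitor of growth, a higher number a weaker inhibitor of growth:
- Compound 1 `COCCCCCCCCCCCCCCC/C=C1\CC(CO)(COC(=O)C(C)(C)C)OC1=O`: 4.65 ug/mL
- Compound 2 `CC(C)(C)C(=O)OCC1(CO)C/C(=C\CCCCCCCCCCCCCCC=O)C(=O)O1`: > 10 ug/mL (a limit of the assay, not a number)

Compound 2 has no exact place on the scale, as it rests on (the limit of > 10 ug/mL in this assay, at which 1 of the 2 values shown sits). Compound 3 `CC(=O)NCCCCCCCCCCCCCCC/C=C1\CC(CO)(COC(=O)C(C)(C)C)OC1=O` has not yet been measured. It carries acetamidomethyl in place of formyl on a saturated chain carbon, ten or more bonds along the chain from a double-bonded chain carbon.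

Going by the values given here, one measured step bears on this change. It concerns the same place on the chain, where formyl replaced methoxymethyl, and it is an at least 2.1-fold higher number from compound 1 to compound 2 (0.33 log units; beyond the scatter). Compound 3 also differs from compound 2 by losing the formyl, so a move toward stronger growth inhibition is expected in this assay. Among the compounds with values here, the size of that move is uncertain, since only a limit is available as its starting point, and a modest change is the most that the single step from compound 1 supports. The expected change is an at least 1.4-fold lower number from compound 2 to compound 3 (0.15 log units; that floor lies within the scatter). For compound 3 the estimate is 7 ug/mL, with an expected range of 3 ug/mL to 16 ug/mL.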

Compound 3, concentration for 50% growth inhibition: > 10 ug/mL
Compound 3: a limit, no number (the forecaster's own chance of this, stated with the estimate: 30%); middle value at least 1.4-fold (0.15 log units) from the limit.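

In this assay compound 3 gives > 10 ug/mL, which is a limit of the assay and not a number. Set against methoxy at the same place on the chain, acetamido gives an at least 2.1-fold higher number from compound 1 to compound 3 (0.33 log units; beyond the scatter) and so weakens growth inhibition, as formyl did, which means that removing the formyl did not by itself restore a measurable value. The step between compound 2 and compound 3 cannot be read, since both compounds rest on a limit: the limit of > 10 ug/mL in this assay, at which 2 of the 3 values shown sit.

On these data alone, how far compound 2 and compound 3 lie beyond that limit stays open, so neither formyl nor acetamido can be ranked as the poorer group at this place. Also open, as far as these compounds go, is whether an amine, a carboxylic acid or a longer chain carrying methoxy at this place would match or pass compound 1 at 4.65 ug/mL in this assay.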